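From chloro to methoxy in the series

The compounds below may be only part of what the source reports. "The series", "measured", "known", "first", "only" and "open" are said of these compounds alone.

Measured in a functional assay on HeLa cells (Homo sapiens) for cytotoxicity, read by MTT assay, with a stated time of 48 h; a lower number here means a stronger inhibitor, a higher number a weaker inhibitor:
- compound 1 `O=C(O)CN1C(=O)/C(=C/c2nc3ccccc3n2Cc2ccc(Br)cc2F)SC1=S`: > 50000 nM (a limit)
- compound 2 `Cc1ccc(Cn2c(/C=C3\SC(=S)N(CC(=O)O)C3=O)nc3ccccc32)cc1`: 1280 nM
- compound 3 `Cc1ccc(Cn2c(/C=C3\SC(=S)N(CC(=O)O)C3=O)nc3cc(Cl)ccc32)cc1`: 21400 nM

Compound 3 at 21400 nM holds the higher of the two true numbers, and compound 2 lies nearest at 1280 nM. The entry for compound 1 is a limit of the assay.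

Compound 4 `COc1ccc2c(c1)nc(/C=C1\SC(=S)N(CC(=O)O)C1=O)n2Cc1ccc(C)cc1` carries methoxy in place of chloro on an aromatic carbon.

The step that bears most directly is the large 17-fold higher number from compound 2 to compound 3 (1.22 log units; beyond the scatter), where chloro replaced hydrogen on an aromatic carbon. The equally large an at least 39-fold lower number from compound 1 to compound 2 (1.59 log units; beyond the scatter) concerns a different part of the molecule and starts from the limit of > 50000 nM in this assay, at which 1 of the 3 values shown sits, so it bears little here. Within the data shown here, no methoxy compound has been measured. Losing the chloro of compound 3 is expected to recover only part of the large 17-fold higher number from compound 2 to compound 3 (1.22 log units; beyond the scatter) in this assay, so a moderate step to a lower number is expected, with wide uncertainty. The expected change is a 2.4-fold lower number from compound 3 to compound 4 (0.38 log units; beyond the scatter). For compound 4 the estimated value is 9000 nM, with an expected range of 2500 nM to 32000 nM.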

Compound 4, half-maximal inhibitory concentration: 1820 nM
The estimate for compound 4 lay 4.9-fold (0.69 log units) above the measured number; measured number outside the range, below it.
By their numbers in this assay, from the lowest: compounds 2 and 4 (each within the scatter of the next); then compound 3. At a limit, above all of these: compound 1.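

In this assay, methoxy in place of chloro on this aromatic carbon gives a 12-fold lower number from compound 3 to compound 4 (1.07 log units; beyond the scatter), so the loss seen with chloro is not shared by every group placed here. Methoxy in place of hydrogen gives a 1.4-fold higher number from compound 2 to compound 4 (0.15 log units; within the scatter), so this carbon can carry a substituent with no change beyond the scatter, which hydrogen and chloro alone could not show. Across these three compounds the outcome follows which group sits here rather than whether one is present, and compound 3 is the one that goes against a substituent here being without effect.

Nothing among the data shown accounts for the wide gap between chloro and methoxy. As far as these compounds go, whether an amine or a hydroxyl group on the same carbon would stay with compound 2 and compound 4 or fall nearer compound 3 remains open.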